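The source may report more compounds than this note shows. Statements on the series, on what has been measured and on what is new or still open speak of the compounds shown alone.

Compound 2, `O=C(N/N=C/N1CCN(c2cc3c(cc2F)c(=O)c(C(=O)O)cn3C2CC2)CC1)c1cccc(C(F)(F)F)c1`, carries a 3-(trifluoromethyl)phenyl group on a carbonyl carbon attached to the shared core. In an ADME assay on PBMC cells (Homo sapiens) for cytotoxicity, read by MTT assay (on this read-out higher numbers stand for weaker inhibition and lower numbers for stronger inhibition), compound 2 reaches only the limit of > 322000 nM, so no number is known for it. Compound 1, `O=C(N/N=C/N1CCN(c2cc3c(cc2F)c(=O)c(C(=O)O)cn3C2CC2)CC1)c1ccc(C(F)(F)F)cc1`, differs from it only in bearing a 4-(trifluoromethyl)phenyl group at that same carbonyl carbon, and in this assay compound 1 gives 347000 nM. The step that the limit leaves unreadable from compound 1 to compound 2 cannot be read in size because of the limit of > 322000 nM in this assay, at which 1 of the 2 values shown sits. Compound 3, `O=C(N/N=C/N1CCN(c2cc3c(cc2F)c(=O)c(C(=O)O)cn3C2CC2)CC1)c1ccc(F)cc1`, is the next variation: 4-fluorophenyl in place of 3-(trifluoromethyl)phenyl on a carbonyl carbon. Among the measured compounds shown here, no measured step bears directly on this change; what the two values show is that compound 1 and compound 2 both sit at the weak end of this assay, and the only measured step between them is unreadable. Compound 3 is therefore expected to stay in the same weak region, with the step that the limit leaves unreadable from compound 2 to compound 3 expected to be no larger than the usual scatter. The estimate for compound 3 is 350000 nM, with a range from 150000 nM to 800000 nM, and a fair chance that only a limit is reported.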

Compound 3, half-maximal inhibitory concentration: > 763000 nM
Compound 3 was reported as a limit; the forecaster's own chance of this, stated with the estimate: 60%; at least 2.1-fold (0.33 log units) between middle value and limit.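

With fluoro in place of trifluoromethyl on the aromatic carbon, this assay gives its first readable step among these compounds, an at least 2.1-fold higher number from compound 1 to compound 3 (0.34 log units; beyond the scatter). On this read-out, the higher number means weaker inhibition, so the smaller 4-fluorophenyl group moves the series further toward the weak end than the 4-(trifluoromethyl)phenyl group does. Compound 3 is recorded only as a limit, > 763000 nM, so this step sets a minimum for the change and does not give its full size, and the two steps involving compound 2 cannot be read at all: the limit of > 322000 nM in this assay, at which 1 of the 3 values shown sits.

The compounds shown carry only fluorine-containing phenyl groups on this carbonyl carbon, so it remains open whether the shift toward weaker inhibition depends on fluoro itself or would also appear with other groups at that ring carbon. A phenyl ring bearing an amine or a carboxylic acid in place of the fluoro, or a longer alkyl chain in place of the phenyl ring, would test how far the weak end of this read-out extends beyond these fluorinated examples.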